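Moving the methoxycarbonyl group: from compound 2 to compound 3

The source may hold more compounds than are shown below. What is called first, only, known or untested is meant among the compounds shown, and "the series" means these compounds.

Compound 1: `N#Cc1ccccc1-c1ccc(CSc2nc(SCc3ccc([N+](=O)[O-])cc3)nc3ccccc23)cc1`, > 100000 nM
Compound 2: `COC(=O)c1ccccc1-c1ccc(CSc2nc(C(C)C)nc3ccccc23)cc1`, > 100000 nM

In an assay on isolated protein for inhibition of phosphodiesterase 7 (Homo sapiens), read by scintillation proximity assay and cAMP accumulation, with a stated time of 1 h (a lower number here means a stronger inhibitor, a higher number a weaker inhibitor), compound 2 gives only a limit of the assay, not a number. The same holds for compound 1, whose value is also a limit. Thus (the limit of > 100000 nM in this assay, at which 2 of the 2 values shown sit); compound 2 stands at that limit, and no measured step exists to guide the next move. Compound 3 `COC(=O)c1ccc(-c2ccc(CSc3nc(C(C)C)nc4ccccc34)cc2)cc1` differs from compound 2 in one place: 4-(methoxycarbonyl)phenyl in place of 2-(methoxycarbonyl)phenyl on an aromatic carbon. With nothing measured on such a change, compound 3 is expected to remain near the limit, the step of an at least 1.2-fold lower number from compound 2 to compound 3 (0.09 log units; that floor lies within the scatter) likely not beyond the scatter. Compound 3 is estimated at 80000 nM, within 10000 nM to 300000 nM.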

Compound 3, half-maximal inhibitory concentration: 33000 nM
Compound 3: the middle estimate sits 2.4-fold (0.38 log units) above what was measured; measured number inside the range.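

In this assay, moving the ester from 2-(methoxycarbonyl)phenyl to 4-(methoxycarbonyl)phenyl brings an at least 3.0-fold lower number from compound 2 to compound 3 (0.48 log units; beyond the scatter), so this position responds to a change that leaves the atoms the same. Compound 3 is the first compound shown to give a number rather than a limit. The full size of the step cannot be read, as compound 2 gives only a limit: the limit of > 100000 nM in this assay, at which 2 of the 3 values shown sit.

As far as these compounds go, whether a carboxylic acid or an amide in place of the methoxycarbonyl group would keep or extend this gain remains open. So does whether a nitrile at this same place would behave alike.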